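Sulfonamide Series: Cytotoxicity Limits and One Unmeasured Amide

The compounds below may be only part of what the source reports. "The series", "measured", "known", "first", "only" and "open" are said of these compounds alone.

Compound 1 `Cc1cc(C)c(S(=O)(=O)N2CCC(C3OCC(C)CO3)CC2)c(C)c1`: in an ADME assay on HCT-116 cells (Homo sapiens) for cytotoxicity, read by CellTiter-Glo, with a stated time of 72 h (on this read-out higher numbers stand for weaker inhibition and lower numbers for stronger inhibition), compound 1 gives > 5000 nM, a limit of the assay rather than a number.
Compound 2 `CC(=O)Nc1ccc(S(=O)(=O)N2CCC(N3CCC(C)CC3)CC2)c2ccccc12`: in this assay compound 2 gives > 10000 nM, again a limit.
Compound 3 `CC1CCN(C2CCN(S(=O)(=O)c3ccc(Cl)c(C(F)(F)F)c3)CC2)CC1`: in this assay compound 3 gives > 5000 nM, also a limit.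

Compound 1 therefore stands at a limit, with no measured number of its own. The same holds for the other two values shown: the limit of > 5000 nM in this assay, at which 2 of the 3 values shown sit, and (the limit of > 10000 nM in this assay, at which 1 of the 3 values shown sits). Every value is a limit. For the measured compounds named here, none of the three compounds can be set apart from another, and no step between two measured compounds is available for comparison.

Compound 4 `CCCC(=O)NC1CCN(S(=O)(=O)c2c(C)cc(C)cc2C)CC1` has not been measured. It differs from compound 1 in one place: a group of 6 heavy atoms (4 carbon, 1 nitrogen, 1 oxygen; no ring) in place of a group of 7 heavy atoms (5 carbon, 2 oxygen; one six-membered non-aromatic ring with 2 hetero atoms), on a saturated ring carbon. The (propylcarbonyl)amino group thus takes the place of the ring on the saturated ring carbon.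

Going by the values given here, with every measured value a limit, there is no measured step to say how large a change this swap might bring. The step from compound 1 to compound 4 is expected to be none beyond the scatter, a step that the limit leaves unreadable from compound 1 to compound 4, most likely ending again at a limit. Compound 4 is estimated at 10000 nM, within a range from 4000 nM to 50000 nM, and the chance that only a limit is reported is judged high.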

Compound 4, half-maximal inhibitory concentration: > 5000 nM
Compound 4: only a limit was reported; the forecaster's own chance of this, stated with the estimate: 85%; the middle value lies beyond the limit too.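

For the compounds shown here, compound 1 and compound 4 each give only a limit of the assay in this assay, not a number, so no step between them can be read. The compounds shown leave open at what concentration any of them would inhibit these cells, and whether the (propylcarbonyl)amino group and the ring it replaces differ at all in this read-out.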